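A few compounds are considered here, and "the series" means these few. Any claim that something is new, unique, unknown or untested is made for them only; others in the source may bear on it.

Compound 1 `CC1=CC[C@@H]([C@@](C)(O)CCCC(C)(C)NC(=S)N/N=C\c2ccccc2)CC1` is the parent of this small set. In a functional assay on NCI/ADR cells (Homo sapiens) for cytotoxicity, read by sulforhodamine B assay (a lower number here means a stronger inhibitor of growth, a higher number a weaker inhibitor of growth), compound 1 gives 6970 nM, the lowest of the two numbers recorded, and the nearest to it is compound 2 `CC1=CC[C@@H]([C@@](C)(O)CCCC(C)(C)NC(=S)N/N=C\c2ccc([N+](=O)[O-])cc2)CC1`, which gives 12800 nM. Compound 3 `CC1=CC[C@@H]([C@@](C)(O)CCCC(C)(C)NC(=S)N/N=C\c2ccccc2Cl)CC1` does not give a number at all: its result is a limit of the assay, > 100000 nM (the limit of > 100000 nM in this assay, at which 1 of the 3 values shown sits).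

Two measured steps lead away from compound 1. The first, a 1.8-fold higher number from compound 1 to compound 2 (0.26 log units; within the scatter), stays within the scatter. The second, an at least 14-fold higher number from compound 1 to compound 3 (1.15 log units; beyond the scatter), is a large loss, and the related step of an at least 7.8-fold higher number from compound 2 to compound 3 (0.89 log units; beyond the scatter) points the same way. No cause for either is shown.

Compound 4 `CC1=CC[C@@H]([C@@](C)(O)CCCC(C)(C)NC(=S)N/N=C\c2cccc(Cl)c2)CC1` is still to be measured. It differs from compound 1 by chloro in place of hydrogen on an aromatic carbon. The change is the same kind of substitution that hurt compound 3, though placed elsewhere on the ring, so a loss seems more likely than a gain, but probably smaller than that of compound 3. Compound 4 is therefore expected to give 18000 nM, somewhere between 5000 nM and 70000 nM, which means an expected step of a 2.6-fold higher number from compound 1 to compound 4 (0.41 log units; beyond the scatter).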

Compound 4, concentration for 50% growth inhibition: 7350 nM
Compound 4: the middle estimate sits 2.4-fold (0.39 log units) above what was measured; low and high end bracket the measured number.
By their numbers in this assay, from the lowest: compounds 1, 4 and 2 (each within the scatter of the next). At a limit, above all of these: compound 3.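

Placed as in 3-chlorophenyl, the chloro group gives a 1.1-fold higher number from compound 1 to compound 4 (0.02 log units; within the scatter), and the step from the nitro analogue gives a 1.7-fold lower number from compound 2 to compound 4 (0.24 log units; within the scatter), so in this assay the parent, the 3-chlorophenyl compound and the 4-nitrophenyl compound cannot be told apart. Moving the chlorine within the ring gives an at least 13-fold lower number from compound 3 to compound 4 (1.13 log units; beyond the scatter), which shows that among these compounds the large loss goes with 2-chlorophenyl rather than with the presence of a chloro group as such. That step has only a lower bound, since the result for compound 3 is a limit and not a number: the limit of > 100000 nM in this assay, at which 1 of the 4 values shown sits.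

With one compound for each chloro placement and no measured property to go with them, these results show that the placement of the chlorine matters but give no reason for the loss with 2-chlorophenyl. From the compounds shown here alone, it remains open whether a different group in the place of that chlorine, such as a methoxy group or an amine, would bring the same loss, and whether 4-chlorophenyl would behave like 4-nitrophenyl.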